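Working notes on the ester side-chain series

This account rests on a few compounds, and the source may have more. Where it says the series, first, only, none or still open, it means among the compounds named here.

Measured so far, in a functional assay on SK-BR-3 cells (Homo sapiens) for antiproliferative activity, read by MTT assay, with a stated time of 72 h; on this read-out lower numbers stand for stronger inhibition and higher numbers for weaker inhibition:
- compound 1 `C/C=C1/[C@H](O[C@@H]2O[C@H](CO)[C@@H](O)[C@H](O)[C@H]2O)OC=C(C(=O)OC)[C@H]1CC(=O)OCCc1ccc(O)cc1`: > 20000 nM
- compound 2 `C/C=C1/[C@H](O[C@@H]2O[C@H](CO)[C@@H](O)[C@H](O)[C@H]2O)OC=C(C(=O)OC)[C@H]1CC(=O)OC`: > 15000 nM
- compound 3 `C/C=C1/[C@H](O[C@@H]2O[C@H](CO)[C@@H](O)[C@H](O)[C@H]2O)OC=C(C(=O)OC)[C@H]1CC(=O)OCCc1ccc2c(c1)OCCO2`: > 20000 nM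

Each value above is a limit of this assay, not a number. Compound 1 sits at a limit, (the limit of > 20000 nM in this assay, at which 2 of the 3 values shown sit). Compound 2 sits at a different limit, (the limit of > 15000 nM in this assay, at which 1 of the 3 values shown sits). Compound 3 likewise sits at a limit, so its standing on the numbers shown is simply that no inhibition was reached within the tested range, the same as for the other two.

The steps among the measured compounds are a step that the two limits leave unreadable from compound 1 to compound 2, a step that the two limits leave unreadable from compound 1 to compound 3 and a step that the two limits leave unreadable from compound 2 to compound 3; since every value is a limit, none of them has a readable size, and no direction can be taken from them.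

Compound 4 `C/C=C1/[C@H](O[C@@H]2O[C@H](CO)[C@@H](O)[C@H](O)[C@H]2O)OC=C(C(=O)OC)[C@H]1CC(=O)OCCc1ccc(OC)cc1` differs from compound 3 by 4-methoxyphenyl in place of 2,3-dihydro-1,4-benzodioxin-6-yl on a saturated chain carbon, two bonds along the chain from an oxygen next to a carbonyl group. Among the compounds with values here, the steps that bear on this are the ester side-chain changes from compound 1 and compound 2 to compound 3, all unreadable, so no step beyond the scatter in either direction can be expected in this assay; the expectation is that compound 4 also sits at a limit, with a step that the limit leaves unreadable from compound 3 to compound 4 as the estimated step.

Compound 4 is therefore estimated at 30000 nM in this assay, within 10000 nM to 100000 nM.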

Compound 4, half-maximal inhibitory concentration: > 20000 nM
Compound 4: only a limit was reported (the forecaster's own chance of this, stated with the estimate: 85%); the middle value lies beyond the limit too.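

In this assay compound 4 gives > 20000 nM, which is a limit of the assay and not a number. Within the data shown here, no step from compound 4 to compound 1, compound 2 or compound 3 can be read. The compounds shown leave open whether any ester side chain in this series gives a measurable value in this assay.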